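A few compounds are considered here, and "the series" means these few. Any claim that something is new, unique, unknown or untested is made for them only; others in the source may bear on it.

Measured in a functional assay on CHO cells for positive allosteric modulation of metabotropic glutamate receptor 2 (Homo sapiens), read by GTPgammaS binding, with a stated time of 30 min; on this read-out higher numbers stand for larger maximal responses and lower numbers for smaller maximal responses:
- compound 1 `CCc1nnc2c(C#N)c(N3CCC(c4ccccc4)CC3)ccn12` gives 247%
- compound 2 `CCCc1nnc2c(C#N)c(N3CCC(c4ccccc4)CC3)ccn12` gives 272%
- compound 3 `CC(C)(C)c1nnc2c(C#N)c(N3CCC(c4ccccc4)CC3)ccn12` gives 207%

Compound 1 stands second highest of the three numbers; compound 2 lies closest, compound 3 furthest. The steps among them: a number 25 percentage points higher from compound 1 to compound 2 (beyond the scatter), with methyl in place of hydrogen on a saturated chain carbon two bonds along the chain from an aromatic carbon; a number 40 percentage points lower from compound 1 to compound 3 (beyond the scatter) and a number 65 percentage points lower from compound 2 to compound 3 (beyond the scatter), each with tert-butyl on the aromatic carbon in place of the straight chain.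

Compound 4 `N#Cc1c(N2CCC(c3ccccc3)CC2)ccn2c(CN3CCCC3)nnc12` is not yet measured in this assay. It differs from compound 1 by pyrrolidin-1-yl in place of methyl on a saturated chain carbon bound to an aromatic carbon. For the measured compounds named here, the step that bears most directly on it is the one from compound 1 to compound 2, a modest rise on lengthening the chain; the two steps to compound 3 show that a bulkier group directly on the aromatic carbon lowered the response. Compound 4 keeps a single saturated chain carbon on the aromatic carbon and extends beyond it, so a step of modest size is expected, direction uncertain, more likely upward than downward. The step expected for compound 4 is a number 8 percentage points higher from compound 1 to compound 4 (within the scatter), with compound 4 estimated at 255% in this assay, within 200% to 305%.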

Compound 4, largest response reached (Emax), in percent of the reference or control that the assay uses: 240%
Compound 4: the middle estimate sits 15 percentage points above what was measured; the range from low to high includes it.
By their numbers in this assay, from the lowest: compound 3; then compounds 4 and 1 (each within the scatter of the next); then compound 2.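

In this assay, the saturated chain carbon bound to an aromatic carbon accepts pyrrolidin-1-yl, a five-membered non-aromatic ring with one hydrogen-bond acceptor, without a step beyond the scatter (a number 7 percentage points lower from compound 1 to compound 4 (within the scatter)). The same group keeps the response clear of the tert-butyl compound (a number 33 percentage points higher from compound 3 to compound 4 (beyond the scatter)) but does not reach the propyl compound (a number 32 percentage points lower from compound 2 to compound 4 (beyond the scatter)), so the rise seen with the straight chain does not carry over to this larger substituent. No measured evidence explains these differences.

The compounds shown leave open whether the ring or its nitrogen counts at this place. A cyclopentyl or a morpholin-4-yl on the same chain carbon would bear on that, and a butyl chain would show whether the straight-chain rise continues.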